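Acid to dimethylamide at the chain end of compound 3

The source may report more compounds than this note shows. Statements on the series, on what has been measured and on what is new or still open speak of the compounds shown alone.

Among the measured compounds shown here, compound 3 `CCc1cc(C(C)=O)c(O)cc1OCCCCCC(C)(C)C(=O)O` gives 73% in an assay on isolated protein for binding affinity to leukotriene B4 receptor 1 (Homo sapiens), tested at 1 uM (on this read-out lower numbers stand for less inhibition and higher numbers for more inhibition at the one concentration tested (going by the name of the read-out)), the highest of the three numbers so far; compound 2 `C=CCc1cc(C(C)=O)c(O)cc1OCCCCCCC#N` with 63% lies within the scatter of it, while compound 1 `COCc1cc(C(C)=O)c(O)cc1OCCCCCCC#N` with 7% lies well below. For the measured compounds named here, the one measured step, a number 56 percentage points higher from compound 1 to compound 2 (beyond the scatter), concerns a different part of the molecule and does not bear on the present change. Compound 4 `CCc1cc(C(C)=O)c(O)cc1OCCCCCCC(=O)N(C)C` differs from compound 3 by (dimethylcarbamoyl)methyl in place of 1-carboxy-1-methylethyl on a saturated chain carbon, five bonds along the chain from an oxygen on an aromatic ring. Going by the values given here, no step shows the effect of this exchange; compound 2 and compound 3 together only show that nitrile and acid ends give numbers within the scatter of each other. A modest fall, a number 15 percentage points lower from compound 3 to compound 4 (beyond the scatter), is therefore expected, and compound 4 is estimated at 58%, between 35% and 78%.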

Compound 4, a percentage reported as inhibition, at one concentration (the size of the read-out at that concentration, not a potency): 61%
The estimate for compound 4 lay 3 percentage points below the measured number; the measured number falls inside the stated range.
By their numbers in this assay, from the lowest: compound 1; then compounds 4, 2 and 3 (each within the scatter of the next, the first and the last beyond it).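

In this assay, the group exchange at this saturated chain carbon gives a number 12 percentage points lower from compound 3 to compound 4 (beyond the scatter), so a free carboxylic acid at the chain end is not required for a substantial number. The entering group has 0 hydrogen-bond donors against 1 in the leaving group, yet the exchange also alters the branching, so these two changes cannot be separated here. Nothing measured accounts for the size of this step.

An unbranched carboxylic acid or a primary amide at the chain end would separate these changes. On these data alone, how a longer chain would read remains open.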